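The source may hold more compounds than are shown below. What is called first, only, known or untested is meant among the compounds shown, and "the series" means these compounds.

Working notes on the series around the core of compound 1. Going by the values given here, in a physicochemical assay for lipophilicity (a lower number here means a more polar compound, a higher number a more lipophilic compound), compound 1 (`CCCCCCc1nc2ccccc2[nH]1`) gives 3.93 and compound 2 (`CCCCCCCc1nc2ccccc2[nH]1`) gives 4.43 as the higher of the two numbers so far, a gap beyond the scatter.

Compound 3 (`CCCCCCCCc1nc2ccccc2[nH]1`) follows from compound 2 by methyl in place of hydrogen on a saturated chain carbon, seven bonds along the chain from an aromatic carbon and so carries methyl in place of hydrogen on a saturated chain carbon, seven bonds along the chain from an aromatic carbon. Among the compounds with values here, the only measured step that bears on this is a number 0.50 log units higher from compound 1 to compound 2 (beyond the scatter) for the same exchange at six bonds along the chain, modest and beyond the scatter. Within the data shown here, one step shows no trend, and no measurement yet tests whether its size carries over to the seventh bond.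

A rise of similar size is expected, with the estimated a number 0.50 log units higher from compound 2 to compound 3 (beyond the scatter) in this assay most likely beyond the scatter. For compound 3 the expected value is 4.93 (estimated range 4.65 to 5.25).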

Compound 3, partition coefficient: 4.93
Estimate against measurement, compound 3: no gap at the digits printed; measured number inside the range.
By their numbers in this assay, from the lowest: compound 1; then compound 2; then compound 3.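

In this assay, methyl in place of hydrogen on a saturated chain carbon, seven bonds along the chain from an aromatic carbon, gives a number 0.50 log units higher from compound 2 to compound 3 (beyond the scatter) and so matches in size the earlier step, a number 0.50 log units higher from compound 1 to compound 2 (beyond the scatter) for the same exchange at six bonds along the chain. The series now holds a second step of this kind, and across these three compounds the printed step size stays the same over the two positions, with none going against it. Going by these compounds alone, the two exchanges together give a number 1.00 log units higher from compound 1 to compound 3 (beyond the scatter), the sum of the single steps, though no measurement at hand bears on why the step keeps its size.

As far as these compounds go, whether a longer chain would continue this rise stays open, since two equal steps fix no trend beyond compound 3. How a carboxylic acid or an amine in place of the entering methyl would move the number also stays open, as the compounds shown differ only by plain saturated chains.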